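The source may hold more compounds than are shown below. What is called first, only, known or untested is meant among the compounds shown, and "the series" means these compounds.

Working notes on the series. In a functional assay on MCF7 cells (Homo sapiens) for cytotoxicity, read by MTT assay, with a stated time of 72 h (on this read-out lower numbers stand for stronger inhibition and higher numbers for weaker inhibition), compound 1 (`O=C(/C=C/c1ccc([N+](=O)[O-])cc1)Nc1cc2c(Nc3ccc(F)c(Cl)c3)ncnc2cc1O[C@H]1CCOC1`) gives 26700 nM and compound 2 (`O=C(/C=C/c1ccccc1[N+](=O)[O-])Nc1cc2c(Nc3ccc(F)c(Cl)c3)ncnc2cc1O[C@H]1CCOC1`) gives 28400 nM. With only these two numbers in hand, compound 2 stands within the scatter of compound 1, and no order can be drawn between them.

Next is compound 3 (`O=C(/C=C/c1ccc(Br)cc1)Nc1cc2c(Nc3ccc(F)c(Cl)c3)ncnc2cc1O[C@H]1CCOC1`), and the change is 4-bromophenyl in place of 2-nitrophenyl on a double-bonded chain carbon bound to a double-bonded chain carbon. Among the measured compounds shown here, one measured step bears on it: a 1.1-fold higher number from compound 1 to compound 2 (0.03 log units; within the scatter), a swap of 4-nitrophenyl for 2-nitrophenyl at the same place, which stays within the scatter. For the measured compounds named here, no measured compound carries 4-bromophenyl, so the data give only weak guidance on this change. On that single step, no shift beyond the scatter is expected in this assay, and no direction is favoured. The expected step is a 1.2-fold lower number from compound 2 to compound 3 (0.07 log units; within the scatter). The estimate for compound 3 is 24000 nM, with an expected range of 9000 nM to 55000 nM.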

Compound 3, half-maximal inhibitory concentration: 32400 nM
Compound 3: the middle estimate sits 1.4-fold (0.13 log units) below what was measured; measured number inside the range.
By their numbers in this assay, from the lowest: compounds 1, 2 and 3 (each within the scatter of the next).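

In this assay the step of a 1.1-fold higher number from compound 2 to compound 3 (0.06 log units; within the scatter) shows that 4-bromophenyl on a double-bonded chain carbon bound to a double-bonded chain carbon stays within the scatter of 2-nitrophenyl, although the two groups differ in atoms and in hydrogen-bond acceptors. The step of a 1.2-fold higher number from compound 1 to compound 3 (0.08 log units; within the scatter) adds a direct reading of bromo in place of nitro on an aromatic carbon, and it too stays within the scatter, so the three compounds show no order among them. Nothing measured speaks to what lies behind these close numbers.

On these data alone, whether an aminophenyl or a carboxyphenyl group at this place would move the number beyond the scatter remains open. Also open, as far as these compounds go, is whether a longer chain carrying the same 4-bromophenyl group would do so.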